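Working notes on two measured analogues and one awaiting assay

This account rests on a few compounds, and the source may have more. Where it says the series, first, only, none or still open, it means among the compounds named here.

Measured compounds:
compound 1 `Cc1ccc(C(=O)CSc2nnc(C)n2N2C(=O)c3ccccc3C2=O)cc1` — > 200000 nM
compound 2 `C=CCSc1nnc(-c2cc(OC)c(OC)c(OC)c2)n1N1C(=O)c2ccccc2C1=O` — > 200000 nM

In a functional assay on A549 cells (Homo sapiens) for cytotoxicity, read by MTT assay, with a stated time of 48 h (on this read-out lower numbers stand for stronger inhibition and higher numbers for weaker inhibition), compound 1 returns only a limit of the assay, > 200000 nM. Compound 2 likewise returns only a limit, > 200000 nM. Both values sit at the limit of > 200000 nM in this assay, at which 2 of the 2 values shown sit, so compound 2 cannot be placed above or below compound 1; neither compound has a number, and no comparison between them is possible. Among the compounds with values here, no step between compounds that differ in one place has been measured.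

Compound 3 `COc1cc(-c2nnc(SCC(=O)c3ccccc3C)n2N2C(=O)c3ccccc3C2=O)cc(OC)c1OC` differs from compound 2 as follows: (2-methylphenyl)carbonyl in place of vinyl on a saturated chain carbon bound to a sulfur. Within the data shown here, the resulting side chain is the one carried by compound 1, which also stands at the limit, while the remaining part of compound 3 matches compound 2.

Since compound 2 gives > 200000 nM and compound 1 gives > 200000 nM, the step from compound 2 to compound 3 is expected to be a number no higher from compound 2 to compound 3 (the limit leaves the size open), nothing beyond the scatter. Compound 3 is therefore expected to stay at the limit, estimated around 200000 nM, within 50000 nM to 600000 nM.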

Compound 3, half-maximal inhibitory concentration: 144000 nM
Estimate against measurement, compound 3: 1.4-fold (0.14 log units) above, and the stated range covers the measured number.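

In this assay, within the data shown here, this position on a saturated chain carbon bound to a sulfur takes (2-methylphenyl)carbonyl in place of vinyl, and compound 3 gives a measurable 144000 nM, the only number in the set. The change is read as an at least 1.3-fold lower number from compound 2 to compound 3 (0.14 log units; that floor lies within the scatter), so only a floor is known and that floor does not establish a real change in cytotoxicity. The other values remain limits of the assay: the limit of > 200000 nM in this assay, at which 2 of the 3 values shown sit.

Going by these compounds, the true size of the step stays open, as does whether the carbonyl or the 2-methylphenyl ring matters more to the number for compound 3. Also open, on these data alone, is how a carboxylic acid, an amine or a longer alkyl chain would read at this position on the core of compound 3.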